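The source may report more compounds than this note shows. Statements on the series, on what has been measured and on what is new or still open speak of the compounds shown alone.

The compounds measured so far:

compound 1 `COc1ccc(-c2csc(N3N=C(c4ccc(C)cc4)CC3c3ccc4c(c3)OCCO4)n2)cc1` with 2680 nM
compound 2 `COc1ccc(C2=NN(c3nc(-c4ccc(OC)cc4)cs3)C(c3ccc4c(c3)OCCO4)C2)cc1` with 2730 nM
compound 3 `COc1ccc(C2=NN(c3nc(-c4ccc(Br)cc4)cs3)C(c3ccc4c(c3)OCCO4)C2)cc1` with 2540 nM

All three numbers come from a functional assay on MCF7 cells (Homo sapiens) for antiproliferative activity, read by MTT assay, with a stated time of 48 h; a lower number here means a stronger inhibitor, a higher number a weaker inhibitor. The three compounds share one core and differ only in a single group on an aromatic carbon. Going from compound 1 to compound 2 exchanges methyl for methoxy there, and the number moves by a 1.0-fold higher number from compound 1 to compound 2 (0.01 log units; within the scatter). Going from compound 2 to compound 3 exchanges methoxy for bromo, with a 1.1-fold lower number from compound 2 to compound 3 (0.03 log units; within the scatter). Neither step is large enough to count as a real change. Compound 3 therefore stands in the same place as compound 1 and compound 2: its value and theirs differ by less than the usual scatter of this kind of measurement, so none of the three can be called the stronger inhibitor.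

Compound 4 `Clc1ccc(C2=NN(c3nc(-c4ccc(Br)cc4)cs3)C(c3ccc4c(c3)OCCO4)C2)cc1` has not yet been measured. It differs from compound 3 by chloro in place of methoxy on an aromatic carbon. The two steps already seen bear directly on this, since each also swapped one small group on an aromatic carbon for another, and both a 1.0-fold higher number from compound 1 to compound 2 (0.01 log units; within the scatter) and a 1.1-fold lower number from compound 2 to compound 3 (0.03 log units; within the scatter) stayed within the scatter. For compound 4 the step in this assay is therefore expected to be a 1.0-fold higher number from compound 3 to compound 4 (0.01 log units; within the scatter), that is, no shift beyond the scatter. For compound 4 the estimated value is 2600 nM, with a range from 1300 nM to 5200 nM.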

Compound 4, half-maximal inhibitory concentration: 2230 nM
Compound 4: middle estimate off by 1.2-fold (0.07 log units), on the high side, within the range that was stated.
By their numbers in this assay, from the lowest: compounds 4, 3, 1 and 2 (each within the scatter of the next).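

For the compounds shown here, the methoxy of compound 3 sits on an aromatic carbon, para to a large group, and this is the first time that group has been exchanged for a halogen with the bromo on the other aryl ring kept in place. In this assay, that exchange gives a 1.1-fold lower number from compound 3 to compound 4 (0.06 log units; within the scatter), so removing the oxygen, the hydrogen-bond acceptor it carries and one heavy atom leaves the number within the scatter. Together with the earlier exchange of methyl for methoxy, which gave a 1.0-fold higher number from compound 1 to compound 2 (0.01 log units; within the scatter), this means that three small groups have now been seen on this ring without a step beyond the scatter, although no information here explains why this position tolerates the change.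

All of these groups are small and uncharged, so the compounds shown leave open whether an amine, a carboxylic acid or a longer chain such as butoxy at this position would produce a step beyond the scatter. They also leave open whether the chloro would give a similar result with a group other than bromo on the other aryl ring.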